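Swapping an isoquinoline for an ethylphenyl on a triazole

The compounds below may be only part of what the source reports. "The series", "measured", "known", "first", "only" and "open" are said of these compounds alone.

Of the compounds shown here, three have been measured in an assay on Sf9 cells for inhibition of protein deacetylase HDAC6 (Homo sapiens), read by fluorescence, with a stated time of 40 min, tested at 100 nM; a lower number here means less inhibition, a higher number more inhibition at the concentration tested (going by the name of the read-out). Compound 1 `COc1ccc(-n2nc(-c3ccccc3)nc2CNc2ccc(C(=O)NO)cc2)cc1` gives 63.4%. Compound 2 `O=C(NO)c1ccc(NCc2nc(-c3cccc4cnccc34)nn2-c2ccccc2)cc1` gives 40.2%, and compound 3 `Nc1ccccc1NC(=O)c1ccc(NCc2nc(-c3ccccc3)nn2-c2ccccc2)cc1` gives 5%. Compound 2 thus stands second of the three: compound 1 lies above it by more than the usual scatter, and compound 3 lies below it, also by more than the scatter.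

The new compound 4 `CCc1ccc(-c2nc(CNc3ccc(C(=O)NO)cc3)n(-c3ccccc3)n2)cc1` is built from compound 2 by one change, (4-ethylphenyl in place of isoquinolin-5-yl on an aromatic carbon), so that 4-ethylphenyl takes the place of isoquinolin-5-yl on an aromatic carbon between two ring nitrogen atoms of the five-membered ring.

For the measured compounds named here, no measured pair isolates exactly this change. Compound 1 carries a plain phenyl at the same place and scores higher than compound 2 in this assay, but it also differs elsewhere, so it is only a loose guide. The expected step from compound 2 to compound 4 is a modest rise, a number 9.8 percentage points higher from compound 2 to compound 4 (within the scatter), with real uncertainty. Compound 4 is therefore expected to give about 50%, somewhere between 30% and 70%.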

Compound 4, a percentage reported as inhibition, at one concentration (the size of the read-out at that concentration, not a potency): 54.6%
For compound 4 the middle estimate is 4.6 percentage points below the measured one; measured number inside the range.
By their numbers in this assay, from the lowest: compound 3; then compound 2; then compounds 4 and 1 (each within the scatter of the next).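

For the compounds shown here, at the aromatic carbon between two ring nitrogen atoms, the pair of compound 2 and compound 4 gives the first comparison that differs in one place only: in this assay, replacing isoquinolin-5-yl with 4-ethylphenyl gives a number 14.4 percentage points higher from compound 2 to compound 4 (beyond the scatter) at this single concentration. This position therefore accepts a single carbon-only aromatic ring with an ethyl chain, and the ring nitrogen and second ring of isoquinolin-5-yl are not needed for the inhibition seen here. The swap alters all of these features at once, so which one accounts for the step cannot be separated, and no further measurement bears on the result.

Going by these compounds, whether an amine, a carboxylic acid or a longer chain such as butyl in place of the ethyl would raise or lower the number remains open. So does whether the same swap would give a similar step on a different core.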